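Swapping a Halogen on the Core of Compound 1

The compounds below may be only part of what the source reports. "The series", "measured", "known", "first", "only" and "open" are said of these compounds alone.

compound 1 `C=CCOc1ccc(F)cc1C(=O)c1cccnc1`: > 100000 nM
compound 2 `O=C(c1cccnc1)c1ccccc1O`: 24600 nM

In a functional assay on MCF7 cells (Homo sapiens) for cytotoxicity, read by sulforhodamine B assay, with a stated time of 48 h (a lower number here means a stronger inhibitor, a higher number a weaker inhibitor), compound 1 gives > 100000 nM, which is a limit of the assay rather than a number (the limit of > 100000 nM in this assay, at which 1 of the 2 values shown sits). In this assay compound 2 gives 24600 nM. Among the compounds with values here, the two values show only that compound 1 sits at the limit while compound 2 yields a measured number. Compound 3 `C=CCOc1ccc(Br)cc1C(=O)c1cccnc1` differs from compound 1 in one place: bromo in place of fluoro on an aromatic carbon. Within the data shown here, no step of this kind has been measured here, so in this assay no change beyond the scatter is expected. Compound 3 is estimated at 80000 nM, within 20000 nM to 300000 nM. The step expected is an at least 1.2-fold lower number from compound 1 to compound 3 (0.09 log units; that floor lies within the scatter).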

Compound 3, half-maximal inhibitory concentration: 92000 nM
Beside the measured number, compound 3's estimate is 1.2-fold (0.06 log units) below it; the measured number falls inside the stated range.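

In this assay, bromo in place of fluoro on this aromatic carbon, para to an allyloxy group, gives an at least 1.0-fold lower number from compound 1 to compound 3 (0.03 log units; that floor lies within the scatter). This swap thus gives a measured number at this position, but the step can be read only as a floor, and that floor does not go beyond the scatter. The value of compound 1 remains a limit of the assay: the limit of > 100000 nM in this assay, at which 1 of the 3 values shown sits.

The compounds shown leave open the true size of this step. They also leave open how chloro or an amine at this position would read.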